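Ring nitrogen substituent and maximal electroshock dose in a spirocyclic series

A few compounds are considered here, and "the series" means these few. Any claim that something is new, unique, unknown or untested is made for them only; others in the source may bear on it.

Measured compounds:
- compound 1 `CC(C)N1C(=O)NC2(CC2c2ccc3cccc(OCc4ccccc4)c3n2)C1=O`: 300 mg/kg
- compound 2 `O=C1NC(=O)C2(CC2c2ccc3cccc(OCc4ccccc4)c3n2)N1`: 300 mg/kg
- compound 3 `Cc1ccc(N2C(=O)NC3(CC3c3ccc4cccc(OCc5ccccc5)c4n3)C2=O)cc1`: 100 mg/kg

All three share one core and differ only in the group on the amide-type nitrogen in the ring. In a functional assay on the whole organism (strain Kunming) with Mus musculus as the target, in the maximal electroshock model, with a stated time of 0.5 h (a lower number here means that less compound is needed, a higher number that more compound is needed for the effect), compound 1, with isopropyl, gives 300 mg/kg, and compound 2, with hydrogen, gives 300 mg/kg; the step of no change at the digits printed from compound 1 to compound 2 (within the scatter) lies within the scatter. Compound 3, with 4-methylphenyl, gives 100 mg/kg and stands lowest of the three, with a 3.0-fold lower number from compound 1 to compound 3 (0.48 log units; beyond the scatter) and a 3.0-fold lower number from compound 2 to compound 3 (0.48 log units; beyond the scatter) both beyond the scatter.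

Compound 4 `CCC(CO)N1C(=O)NC2(CC2c2ccc3cccc(OCc4ccccc4)c3n2)C1=O` is not yet measured. Its change from compound 3 is 1-(hydroxymethyl)propyl in place of 4-methylphenyl on an amide-type nitrogen in a ring. Among the compounds with values here, the steps that bear on it are those from an open-chain or hydrogen substituent to 4-methylphenyl, a 3.0-fold lower number from compound 1 to compound 3 (0.48 log units; beyond the scatter) and a 3.0-fold lower number from compound 2 to compound 3 (0.48 log units; beyond the scatter). Going the other way, from the aryl group to a chain, the number is expected to rise by about the same modest amount, a 3.0-fold higher number from compound 3 to compound 4 (0.48 log units; beyond the scatter). Within the data shown here, compound 4 is therefore estimated at 300 mg/kg, with a range of 100 mg/kg to 1000 mg/kg; the hydroxyl group has no measured counterpart here, so the range is kept wide.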

Compound 4, minimum effective dose: 30 mg/kg
Compound 4: the middle estimate sits 10-fold (1.00 log units) above what was measured; the measured number lies below the stated range.
By their numbers in this assay, from the lowest: compound 4; then compound 3; then compounds 1 and 2 (each within the scatter of the next).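

At this ring nitrogen, an aryl group is not required for the lowest number in this assay, as the open-chain 1-(hydroxymethyl)propyl group goes past 4-methylphenyl, with a 3.3-fold lower number from compound 3 to compound 4 (0.52 log units; beyond the scatter). Open-chain groups do not act as one class here: a 10-fold lower number from compound 1 to compound 4 (1.00 log units; beyond the scatter) separates two of them, and a 10-fold lower number from compound 2 to compound 4 (1.00 log units; beyond the scatter) shows a step away from the unsubstituted nitrogen that isopropyl did not give. Nothing shown accounts for the lower dose with this chain.

The compounds shown do not separate the hydroxyl from the carbon chain that carries it, so a plain 1-methylpropyl group would be the direct comparison. Also open, on these data alone, is how an amine or a carboxylic acid in place of the hydroxyl, or a longer chain, would read in this assay.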